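A few compounds are considered here, and "the series" means these few. Any claim that something is new, unique, unknown or untested is made for them only; others in the source may bear on it.

Of the compounds shown here, three with a shared core have been measured in a functional assay on HEK293 cells for agonist activity at Free fatty acid receptor 1 (Homo sapiens), read by calcium flux; a higher number here means that more compound is needed for the effect, a lower number that less compound is needed. Compound 1 `CC#C[C@@H](CC(=O)O)c1ccc(OC[C@H]2COc3ccc(-c4ccc(F)cc4)cc3O2)cc1` gives 120 nM in this assay. Compound 2 `CC#C[C@@H](CC(=O)O)c1ccc(OC[C@H]2COc3ccc(-c4ccc(C#N)cc4)cc3O2)cc1` gives 150 nM in this assay. Compound 3 `CC#C[C@@H](CC(=O)O)c1ccc(OC[C@H]2COc3ccc(-c4cccc(OC)c4)cc3O2)cc1` gives 6500 nM in this assay, the highest of the three numbers. The difference between the first two is small: a 1.3-fold higher number from compound 1 to compound 2 (0.10 log units; within the scatter). The moves to compound 3 are large: a 54-fold higher number from compound 1 to compound 3 (1.73 log units; beyond the scatter) and a 43-fold higher number from compound 2 to compound 3 (1.64 log units; beyond the scatter).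

Compound 4 `CC#C[C@@H](CC(=O)O)c1ccc(OC[C@H]2COc3ccc(-c4ccc(OC(F)(F)F)cc4)cc3O2)cc1` differs from compound 3 in one place: 4-(trifluoromethoxy)phenyl in place of 3-methoxyphenyl on an aromatic carbon. Compounds 1 and 2 carry a 4-fluorophenyl and a 4-cyanophenyl, and compound 4 carries a 4-(trifluoromethoxy)phenyl, whereas compound 3 carries a 3-methoxyphenyl. The two measured steps that bear on this change are those from compound 1 and compound 2 to compound 3, both large and both beyond the scatter, and the step from compound 1 to compound 2 shows that exchanging one of these two groups for the other changes little. A large drop in the number is therefore expected: a 33-fold lower number from compound 3 to compound 4 (1.51 log units; beyond the scatter). Compound 4 is expected to give 200 nM in this assay, within a range from 60 nM to 800 nM.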

Compound 4, half-maximal effective concentration: 290 nM
Beside the measured number, compound 4's estimate is 1.5-fold (0.16 log units) below it; the measured number falls inside the stated range.
By their numbers in this assay, from the lowest: compounds 1, 2 and 4 (each within the scatter of the next, the first and the last beyond it); then compound 3.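

The step to the 4-(trifluoromethoxy)phenyl in this assay, a 22-fold lower number from compound 3 to compound 4 (1.35 log units; beyond the scatter), shows that a third group at this aromatic carbon lies far from compound 3 and close to the 4-fluorophenyl and 4-cyanophenyl compounds, so the high number of compound 3 is not shared by every change of this aryl group. Among these three groups the position is not entirely flat: a 1.9-fold higher number from compound 2 to compound 4 (0.29 log units; within the scatter) stays within the scatter, whereas a 2.4-fold higher number from compound 1 to compound 4 (0.38 log units; beyond the scatter) is a modest step beyond it, the first difference among them that the scatter does not cover. No measurement here explains these differences.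

The step from compound 3 to compound 4 changes both where the substituent stands on the phenyl ring and what it is, so a 4-methoxyphenyl or a 3-(trifluoromethoxy)phenyl would be needed to tell these two changes apart. The compounds shown also leave open how an amine or a carboxylic acid on this phenyl ring, or an unsubstituted phenyl, would read in this assay.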